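This account rests on a few compounds, and the source may have more. Where it says the series, first, only, none or still open, it means among the compounds named here.

Within the data shown here, compound 1 `C=C1C2=C(C(=O)N1OC)[C@H](O)[C@@](C)(O)[C@H](CCCCC)O2` carries a free hydroxy on its shared core, and in an ADME assay on HEF cells (Homo sapiens) for cytotoxicity, read by MTT assay, with a stated time of 72 h (a higher number here means a weaker inhibitor, a lower number a stronger inhibitor), compound 1 gives 19000 nM, the highest of the two numbers measured so far. Compound 2 `C=C1C2=C(C(=O)N1OC)[C@H](OC(=O)CSc1nc3ccccc3[nH]1)[C@@](C)(O)[C@H](CCCCC)O2`, which carries a larger ester at the same oxygen, gives 11000 nM in this assay; the two numbers lie within the usual scatter of each other, so they show no difference that can be read. Compound 3 `C=C1C2=C(C(=O)N1OC)[C@H](OC(=O)CCl)[C@@](C)(O)[C@H](CCCCC)O2` has not yet been measured. It differs from compound 1 in one place: (chloromethyl)carbonyl in place of hydrogen on an oxygen on a saturated carbon. Because compound 2 gives 11000 nM with an ester at the same place, close to the number for compound 1, a large step is not expected for compound 3. The step from compound 1 to compound 3 is expected to be small, a 1.6-fold lower number from compound 1 to compound 3 (0.20 log units; within the scatter), toward a slightly lower number if anything, and most likely not beyond the scatter. Compound 3 is therefore estimated to give about 12000 nM in this assay, with a range from 5000 nM to 30000 nM.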

Compound 3, half-maximal inhibitory concentration: 9100 nM
Compound 3: the middle estimate sits 1.3-fold (0.12 log units) above what was measured, and the stated range covers the measured number.
By their numbers in this assay, from the lowest: compounds 3, 2 and 1 (each within the scatter of the next, the first and the last beyond it).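

Among these compounds, at this oxygen on a saturated carbon, the change from hydroxy to ((chloromethyl)carbonyl)oxy gives in this assay what is printed as a 2.1-fold lower number from compound 1 to compound 3 (0.32 log units; beyond the scatter) and is the first step at this position that can be read, although it is only modest. The ester end also changes, with chloro in place of (1H-benzimidazol-2-yl)sulfanyl on a saturated chain carbon bound to a carbonyl carbon, and this gives a 1.2-fold lower number from compound 2 to compound 3 (0.08 log units; within the scatter) so these two esters cannot be told apart here despite their very different end groups. No supporting measurement is available to explain the step from the free hydroxy to the ester.

On these data alone, it remains open whether the chlorine matters at all, since a plain acetyl ester, with a methyl group in place of the chloromethyl group, would separate the effect of the chlorine from that of the ester link. As far as these compounds go, it also remains open how this position responds to a link of another kind, such as a methyl ether, or to an ester whose chain ends in an amine or a carboxylic acid.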